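Inverting Both Stereocentres of Compound 1

The source may report more compounds than this note shows. Statements on the series, on what has been measured and on what is new or still open speak of the compounds shown alone.

For the measured compounds named here, in a functional assay on A549 cells (Homo sapiens) for cytotoxicity, read by MTT assay, with a stated time of 48 h (on this read-out lower numbers stand for stronger inhibition and higher numbers for weaker inhibition), compound 1 (`CCOC(=O)[C@@]1(C(=O)NCc2ccc(C)cc2)C[C@H]1c1cc(OC)c(OC)c(OC)c1`) gives 17100 nM and stands lowest of the three numbers so far. Compound 2 (`COc1cc([C@@H]2C[C@@]2(CO)C(=O)NCc2ccc(C)cc2)cc(OC)c1OC`) gives 46300 nM and compound 3 (`CCOC(=O)[C@@]1(C(=O)Nc2ccccc2)C[C@H]1c1cc(OC)c(OC)c(OC)c1`) gives 65900 nM in the same test. Hydroxymethyl in place of ethoxycarbonyl on a saturated ring carbon gave a 2.7-fold higher number from compound 1 to compound 2 (0.43 log units; beyond the scatter) and phenyl in place of 4-methylbenzyl on an amide-type nitrogen gave a 3.9-fold higher number from compound 1 to compound 3 (0.59 log units; beyond the scatter) as the second modest step. Compound 4 (`CCOC(=O)[C@]1(C(=O)NCc2ccc(C)cc2)C[C@@H]1c1cc(OC)c(OC)c(OC)c1`) is still unmeasured and relates to compound 1 by a change in configuration alone (the two compounds have the same atoms and bonds and differ only in configuration as drawn: 2 of 2 stereo elements differ (all stereocentres are inverted: mirror images); a stereocentre at a saturated ring carbon is drawn S in compound 1 and R in compound 4; a stereocentre at a saturated ring carbon is drawn S in compound 1 and R in compound 4) with the same atoms and bonds throughout. Neither measured step touches configuration, so both serve only as a gauge of size. Compound 1 at 17100 nM has nothing measured beneath it, so a modest rise is expected rather than a fall, though the direction is not secure. The step expected is a 1.6-fold higher number from compound 1 to compound 4 (0.21 log units; within the scatter) and remains an estimate. For compound 4 the expected value is 28000 nM within an estimated range of 10000 nM to 80000 nM on this read-out.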

Compound 4, half-maximal inhibitory concentration: 34900 nM
Estimate against measurement, compound 4: 1.2-fold (0.10 log units) below; measured number inside the range.
By their numbers in this assay, from the lowest: compound 1; then compounds 4, 2 and 3 (each within the scatter of the next).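

Where the earlier steps exchanged one group for another, this change leaves every atom and bond in place, yet in this assay it still gives a 2.0-fold higher number from compound 1 to compound 4 (0.31 log units; beyond the scatter) on the mirror-image pair. The gap can be set on configuration alone, because nothing else separates the pair: the fact that compounds 1 and 4 differ only in the configuration as drawn. Both stereocentres are inverted together, so the modest step belongs to the pair of them and cannot be divided between the two saturated ring carbons.

Still open, as far as these compounds go, is what inverting either stereocentre alone would do, and whether the same gap between mirror images holds with the hydroxymethyl of compound 2 or the phenyl of compound 3. Also open, from the compounds shown here alone, is how either configuration would read with a carboxylic acid in place of ethoxycarbonyl on the saturated ring carbon.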